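Capping the hydroxy group of compound 3

The source may hold more compounds than are shown below. What is called first, only, known or untested is meant among the compounds shown, and "the series" means these compounds.

Compound 1 `CC1=CSC(O)(c2ccccc2)c2noc(=O)n21`: 230 nM
Compound 2 `CC1=CSC(OC(C)C)(c2ccccc2)c2noc(=O)n21`: 1190 nM
Compound 3 `COc1ccc(C2(O)SC=C(C)n3c2noc3=O)cc1`: 520 nM

In a functional assay (Left cardiac atrium, Cavia porcellus), with a stated time of 30 min (a higher number here means that more compound is needed for the effect, a lower number that less compound is needed), compound 3 gives 520 nM, the second highest of the three numbers. Compound 1 sits lower at 230 nM, and compound 2 sits higher at 1190 nM.

Compound 4 `COc1ccc(C2(OCC3CCCCC3)SC=C(C)n3c2noc3=O)cc1` has cyclohexylmethyl in place of hydrogen on an oxygen on a saturated carbon.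

One measured change resembles this closely. Placing isopropyl on the same oxygen gave a 5.2-fold higher number from compound 1 to compound 2 (0.71 log units; beyond the scatter). The other measured change, methoxy in place of hydrogen on an aromatic carbon, gave a 2.3-fold higher number from compound 1 to compound 3 (0.35 log units; beyond the scatter). That methoxy is already present in compound 3 and stays unchanged, so it bears on the new step only indirectly. For the measured compounds named here, no measured compound carries cyclohexylmethyl, and the isopropyl step was measured without the methoxy, so the range must stay wide.

A step of similar size and the same direction is therefore expected, estimated as a 4.8-fold higher number from compound 3 to compound 4 (0.68 log units; beyond the scatter). Compound 4 is estimated at 2500 nM, with an expected range of 800 nM to 8000 nM.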

Compound 4, half-maximal effective concentration: 660 nM
The estimate for compound 4 lay 3.8-fold (0.58 log units) above the measured number; measured number below the stated range.
By their numbers in this assay, from the lowest: compound 1; then compounds 3, 4 and 2 (each within the scatter of the next, the first and the last beyond it).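

In this assay, cyclohexylmethyl on this oxygen gives a 1.3-fold higher number from compound 3 to compound 4 (0.10 log units; within the scatter), so with the methoxy present, the capped compound and its hydroxy parent cannot be told apart. The earlier isopropyl cap gave a 5.2-fold higher number from compound 1 to compound 2 (0.71 log units; beyond the scatter), so capping this oxygen does not produce one fixed step across these compounds. Nothing shown here explains why the two steps differ.

From the compounds shown here alone, the two steps differ in both the capping group and the methoxy, so it remains open which of these sets them apart. Also open, going by these compounds, is how this position would respond to a cap of another kind, such as a chain ending in an amine or a carboxylic acid.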